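A few compounds are considered here, and "the series" means these few. Any claim that something is new, unique, unknown or untested is made for them only; others in the source may bear on it.

Compound 1 `O=C(Nc1cccc(-n2cc(-c3ccncc3)c(-c3cc(O)cc(Cl)c3)n2)c1)Nc1ccc(Cl)c(Cl)c1`: 97%
Compound 2 `COc1cc(Cl)cc(-c2nn(-c3cccc(NC(=O)Nc4ccc(Cl)c(Cl)c4)c3)cc2-c2ccncc2)c1`: 101%

Both were tested in a functional assay on OVCAR-8 cells (Homo sapiens) for inhibition, read by sulforhodamine B assay, with a stated time of 48 h, tested at 0.1 uM; on this read-out higher numbers stand for a weaker effect at the one concentration tested and lower numbers for a stronger effect. Compound 2 and compound 1 lie within the scatter of each other, so neither can be called the stronger; at the single concentration used, both leave most of the cell growth in place. For the measured compounds named here, the only step in hand, a number 4 percentage points higher from compound 1 to compound 2 (within the scatter), came from methyl in place of hydrogen on an oxygen on an aromatic ring and changed little.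

Compound 3 `COc1cc(Cl)cc(-c2nn(-c3cccc(NC(=O)c4cccc(C(F)(F)F)c4)c3)cc2-c2ccncc2)c1` has not yet been measured. It differs from compound 2 by 3-(trifluoromethyl)phenyl in place of (3,4-dichlorophenyl)amino on a carbonyl carbon. Going by the values given here, no measured step touches this part of the molecule: the single step of a number 4 percentage points higher from compound 1 to compound 2 (within the scatter) concerns the oxygen on the other aromatic ring and says nothing about what happens at the carbonyl carbon. With nothing to draw on beyond the two measured values, the expectation for compound 3 is that its number stays near those of compounds 1 and 2, and the step of a number 5 percentage points lower from compound 2 to compound 3 (within the scatter) is expected to fall within the scatter, though a larger change cannot be excluded. Compound 3 is therefore estimated at 96%, ranging from 75% to 110%.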

Compound 3, a percentage reported as activity, at one concentration (the size of the read-out at that concentration, not a potency): 94%
The estimate for compound 3 lay 2 percentage points above the measured number; low and high end bracket the measured number.
By their numbers in this assay, from the lowest: compounds 3, 1 and 2 (each within the scatter of the next).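

The change at the carbonyl carbon is far larger than the earlier one on the oxygen, yet it gives a number 7 percentage points lower from compound 2 to compound 3 (within the scatter) in this assay. The (3,4-dichlorophenyl)amino group, with its 2 chlorine atoms and 1 hydrogen-bond donor, gives way to 3-(trifluoromethyl)phenyl, with 3 fluorine atoms and 0 hydrogen-bond donors, and at this single concentration the read-out does not separate the two, so this position tolerates a substantial rebuild without a measurable gain or loss, though this holds for this one pair alone. No measured evidence is available that could explain this result.

Because all three compounds leave most of the cell growth in place, a single concentration cannot show whether the two groups would differ at higher concentrations, where an effect might become visible. On these data alone, it also remains open whether a quite different group on the same carbonyl carbon, such as a cyclohexyl ring, a morpholine or a phenyl ring carrying a carboxylic acid, would move the number beyond the scatter.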